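The source may hold more compounds than are shown below. What is called first, only, known or untested is meant among the compounds shown, and "the series" means these compounds.

- compound 1 `COc1ccc(CN(C(=O)CSc2nc3ccccc3s2)c2cc(OC)c(OC)c(OC)c2)cc1Br`: 4550 nM
- compound 2 `COc1cc(N(Cc2ccc(F)cc2)C(=O)CSc2nc3ccccc3s2)cc(OC)c1OC`: 59800 nM

In a functional assay on HCT-116 cells (Homo sapiens) for antiproliferative activity, read by MTT assay, with a stated time of 48 h (on this read-out lower numbers stand for stronger inhibition and higher numbers for weaker inhibition), compound 2 gives 59800 nM, the higher and therefore weaker of the two values. Compound 3 `COc1cc(N(Cc2ccc(Br)cc2)C(=O)CSc2nc3ccccc3s2)cc(OC)c1OC` has bromo in place of fluoro on an aromatic carbon of compound 2: bromo in place of fluoro on an aromatic carbon. For the measured compounds named here, one measured step bears on this. On these data alone, the large 13-fold higher number from compound 1 to compound 2 (1.12 log units; beyond the scatter) also loses a bromo, but it replaces the whole 3-bromo-4-methoxyphenyl, so the bromo's share remains unknown. A modest move towards a lower number is therefore expected, with an estimated 2.7-fold lower number from compound 2 to compound 3 (0.43 log units; beyond the scatter). The estimate for compound 3 is 22000 nM, with an expected range from 6000 nM to 70000 nM.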

Compound 3, half-maximal inhibitory concentration: 63800 nM
For compound 3 the middle estimate is 2.9-fold (0.46 log units) below the measured one; the range from low to high includes it.
By their numbers in this assay, from the lowest: compound 1; then compounds 2 and 3 (each within the scatter of the next).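

In this assay, bromo and fluoro at this spot, para to a large group, cannot be told apart: a 1.1-fold higher number from compound 2 to compound 3 (0.03 log units; within the scatter). Having a bromo on this ring is therefore not enough to match compound 1, since 4-bromophenyl still leaves a 14-fold higher number from compound 1 to compound 3 (1.15 log units; beyond the scatter). Nothing measured here explains this result. On these data alone, it stays open whether the methoxy or the placement of the bromo in the 3-bromo-4-methoxyphenyl group accounts for the gap. As far as these compounds go, how an amine or a carboxylic acid in place of the halogen would read also remains unknown.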